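Swapping Fluoro for Chloro on a Serotonin Receptor Ligand

The source may hold more compounds than are shown below. What is called first, only, known or untested is meant among the compounds shown, and "the series" means these compounds.

Four close relatives of one sulfonyl-bearing scaffold are compared in an assay on HeLa cells for displacement of a labelled ligand from 5-hydroxytryptamine receptor 6 (Homo sapiens); on this read-out lower numbers stand for stronger inhibition and higher numbers for weaker inhibition. Compound 1 `CN1CCC(n2cc(S(=O)(=O)c3ccccc3F)c3cccnc32)C1` gives 5.6 nM. Compound 2 `CN1CCC(n2cc(S(=O)(=O)c3ccccc3Cl)c3cccnc32)C1` differs from it by chloro in place of fluoro on an aromatic carbon, and compound 2 gives 2.2 nM; that swap brought a 2.5-fold lower number from compound 1 to compound 2 (0.41 log units; beyond the scatter). Compound 3 `CCN1CCC(n2cc(S(=O)(=O)c3cccc(F)c3)c3cccnc32)C1` carries a different core, and the difference between the two cores is not broken down here; in this assay compound 3 gives 8.3 nM.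

Compound 4 `CCN1CCC(n2cc(S(=O)(=O)c3cccc(Cl)c3)c3cccnc32)C1` has not yet been measured. It differs from compound 3 by chloro in place of fluoro on an aromatic carbon. Going by the values given here, this is the same kind of change as the one between compound 1 and compound 2, but not the same change: in the earlier pair the swapped atom sits ortho to a large group, whereas here it sits meta to a large group, and the two cores also differ.

Among the compounds with values here, only one measured example of this swap exists, so the expectation rests on it alone. In this assay compound 4 is expected to show a 2.1-fold lower number from compound 3 to compound 4 (0.32 log units; beyond the scatter), because the earlier swap of the same kind gave a 2.5-fold lower number from compound 1 to compound 2 (0.41 log units; beyond the scatter). The unlike place of the change and the unlike core make the size uncertain, so the range is kept wide. The estimate for compound 4 is 4 nM, expected to fall between 1.5 nM and 11 nM.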

Compound 4, inhibition constant: 3.3 nM
The estimate for compound 4 lay 1.2-fold (0.08 log units) above the measured number; measured number inside the range.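

In this assay, chloro in place of fluoro on an aromatic carbon gave a 2.5-fold lower number from compound 3 to compound 4 (0.40 log units; beyond the scatter), so on the core of compound 3 the swap moved the number in the same direction, toward stronger inhibition, as it did on the core of compound 1. The two steps can be set side by side, and they agree in size: the same change on two cores in this assay, a 2.5-fold lower number (0.41 log units; beyond the scatter) from compound 1 to compound 2 and a 2.5-fold lower number (0.40 log units; beyond the scatter) from compound 3 to compound 4, 1.0-fold (0.01 log units) apart, within the scatter of two such steps. This shows that, in these two pairs, the size of the swap held up despite a different core and a different place on the aromatic ring, but two pairs are a small sample, they say nothing about why chloro gives the lower number, and they cannot promise the same step on any further core in this series.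

The compounds shown leave open whether another group in that place, such as bromo, methoxy or nitrile, would lower the number further or raise it again. They also leave open whether the swap keeps its size when a longer chain, such as propyl, takes the place of the ethyl group of compound 4.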